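This account rests on a few compounds, and the source may have more. Where it says the series, first, only, none or still open, it means among the compounds named here.

Three measured compounds share one core and differ only in the aryl group on the ring nitrogen: compound 2 `O=C1c2ccccc2S(=O)(=O)N1CCCCCCN1CCN(c2ccc(Cl)c(Cl)c2)CC1`, compound 1 `O=C1c2ccccc2S(=O)(=O)N1CCCCCCN1CCN(c2ccccc2F)CC1` and compound 3 `COc1cccc(N2CCN(CCCCCCN3C(=O)c4ccccc4S3(=O)=O)CC2)c1`. In an ADME assay on HEK293 cells for displacement of a labelled ligand from 5-hydroxytryptamine receptor 7 (Homo sapiens), read by radioligand binding, with a stated time of 1 h (on this read-out higher numbers stand for weaker inhibition and lower numbers for stronger inhibition), compound 2 gives 258 nM; compound 1 gives 322 nM and compound 3 gives 305 nM. The number for compound 2 sits at the low end of the three, but nothing separates it from the others, since a 1.2-fold lower number from compound 1 to compound 2 (0.10 log units; within the scatter) and a 1.2-fold higher number from compound 2 to compound 3 (0.07 log units; within the scatter), and likewise a 1.1-fold lower number from compound 1 to compound 3 (0.02 log units; within the scatter), all stay within the scatter. Compound 4 `O=C1c2ccccc2S(=O)(=O)N1CCCCCCN1CCN(c2cccc3ccccc23)CC1` is unmeasured; its change from compound 2 is naphthalen-1-yl in place of 3,4-dichlorophenyl on an amine nitrogen in a ring. The three measured steps all swap the aryl group on the ring nitrogen and all stay within the scatter. None of them brings in naphthalen-1-yl, so the data say nothing specific about that group. The expected step in this assay is therefore none beyond the scatter, a 1.0-fold higher number from compound 2 to compound 4 (0.00 log units; within the scatter). Compound 4 is estimated at 260 nM, with a range from 90 nM to 750 nM.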

Compound 4, inhibition constant: 20 nM
Compound 4: middle estimate off by 13-fold (1.11 log units), on the high side; measured number outside the range, below it.
By their numbers in this assay, from the lowest: compound 4; then compounds 2, 3 and 1 (each within the scatter of the next).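

In this assay the aryl group on the ring nitrogen proves able to move the number a long way: naphthalen-1-yl gives a 13-fold lower number from compound 2 to compound 4 (1.11 log units; beyond the scatter) and a 15-fold lower number from compound 3 to compound 4 (1.18 log units; beyond the scatter) and also a 16-fold lower number from compound 1 to compound 4 (1.21 log units; beyond the scatter), although 2-fluorophenyl, 3-methoxyphenyl and 3,4-dichlorophenyl stay within the scatter of one another. Among these four compounds, only compound 4 carries two six-membered aromatic rings of carbon only on this nitrogen, and only compound 4 stands apart. Nothing available explains the size of this step.

With a single example, it remains unsettled whether any second aromatic ring on this nitrogen gives the same result or only naphthalen-1-yl does. An indole or a quinoline in this place would test that, and a shorter chain on the shared core would show whether the step holds with a different linker.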